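Methoxy to hydroxy: compound 2 to compound 3

The source may hold more compounds than are shown below. What is called first, only, known or untested is meant among the compounds shown, and "the series" means these compounds.

Among the compounds with values here, compound 2 `COc1cc(-c2nn(-c3cccc(NC(=O)Nc4ccc(Cl)c(C(F)(F)F)c4)c3)cc2-c2ccncc2)ccc1Cl` gives 10300 nM in a functional assay on SNB-75 cells (Homo sapiens) for inhibition, read by sulforhodamine B assay, with a stated time of 48 h (a higher number here means a weaker inhibitor of growth, a lower number a stronger inhibitor of growth), the only number so far. Compound 1 `O=C(Nc1cccc(-n2cc(-c3ccncc3)c(-c3ccc(Cl)c(O)c3)n2)c1)Nc1cccc(C(F)(F)F)c1` reaches only the assay limit of > 32500 nM in this assay, which is the limit of > 32500 nM in this assay, at which 1 of the 2 values shown sits. Compound 3 `O=C(Nc1cccc(-n2cc(-c3ccncc3)c(-c3ccc(Cl)c(O)c3)n2)c1)Nc1ccc(Cl)c(C(F)(F)F)c1` follows from compound 2 by hydrogen in place of methyl on an oxygen on an aromatic ring, methoxy becoming hydroxy on the 4-chloro-3-methoxyphenyl. Within the data shown here, no measured pair differs in this way alone, and compound 1, which also carries the hydroxy, differs from compound 2 in a second place. Compound 3 is expected at 20000 nM, between 6000 nM and 60000 nM, a step of a 1.9-fold higher number from compound 2 to compound 3 (0.29 log units; within the scatter) toward weaker growth inhibition, with a real chance that only a limit is reported.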

Compound 3, concentration for total growth inhibition: 3200 nM
For compound 3 the middle estimate is 6.3-fold (0.80 log units) above the measured one, outside the stated range (below it).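

In this assay, the hydroxy on the 4-chloro-3-hydroxyphenyl outperforms the methoxy, with a 3.2-fold lower number from compound 2 to compound 3 (0.51 log units; beyond the scatter), so this oxygen substituent affects growth inhibition in this series. With the hydroxy held constant, chloro in place of hydrogen on an aromatic carbon gives an at least 10-fold lower number from compound 1 to compound 3 (1.00 log units; beyond the scatter), which shows that a second place also matters. That step is only a bound, as compound 1 stands at a limit and not at a number: the limit of > 32500 nM in this assay, at which 1 of the 3 values shown sits.

As far as these compounds go, whether the methoxy to hydroxy step holds without that chloro remains open. An amine in place of the hydroxy, or ethoxy in place of the methoxy, would show how far the effect at this oxygen extends.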